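From diethylamino to diisopropylamino in a growth test

The source may report more compounds than this note shows. Statements on the series, on what has been measured and on what is new or still open speak of the compounds shown alone.

Compound 1 `Cc1cc(=O)c2c(O)cc(OCc3ccccc3Br)c([C@H]3CCN(C)C[C@H]3O)c2o1`: 32%
Compound 2 `Cc1cc(=O)c2c(O)cc(O)c([C@H]3CCN(C)C[C@H]3OC(=O)c3ccco3)c2o1`: 23%
Compound 3 `CCN(CC)Cc1c(O)c([C@H]2CCN(C)C[C@H]2O)c2oc(C)cc(=O)c2c1O`: 2%

In a functional assay on PC-3 cells (Homo sapiens) for inhibition, read by MTT assay, with a stated time of 48 h, tested at 10 uM (on this read-out higher numbers stand for more inhibition of growth at the one concentration tested and lower numbers for less inhibition of growth), compound 3 stands lowest of the three at 2% and lies beyond the scatter from both others. Compound 2 reads 23% on the same scale, and compound 1 reads 32% there.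

Compound 4 `Cc1cc(=O)c2c(O)c(CN(C(C)C)C(C)C)c(O)c([C@H]3CCN(C)C[C@H]3O)c2o1` has not yet been measured. It carries diisopropylamino in place of diethylamino on a saturated chain carbon bound to an aromatic carbon. Among the measured compounds shown here, no two measured compounds differ in one place only, so the data offer no direct precedent for a step of this kind. Neither compound 1 nor compound 2 carries diethylamino, so the expectation rests mainly on compound 3 at 2% as its starting point.

Little movement is expected in this assay and no step beyond the scatter. The expected change is a number 5 percentage points higher from compound 3 to compound 4 (within the scatter) in this estimate. Compound 4 is estimated at 7% with an expected range from 0% to 20% on this scale.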

Compound 4, percent growth inhibition at one concentration: 0%
The estimate for compound 4 lay 7 percentage points above the measured number; measured number inside the range.
By their numbers in this assay, from the lowest: compounds 4 and 3 (each within the scatter of the next); then compounds 2 and 1 (each within the scatter of the next).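

In this assay, among the compounds shown here, diisopropylamino in place of diethylamino on a saturated chain carbon bound to an aromatic carbon gives a number 2 percentage points lower from compound 3 to compound 4 (within the scatter), the first single-place step that can be read at this position. Compound 3 reads 2% and compound 4 reads 0%, both close to the bottom of the scale, so this change between the two amines brought no gain in inhibition of growth. No measurement shown accounts for this result.

The compounds shown leave open whether a cyclic amine such as morpholine or piperidine at this place would read any differently. They also leave open what a primary amine would do there, or a carboxylic acid on the same saturated chain carbon.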